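Methyl for Iodo on the Benzoyl Ring of a Bisacylhydrazine

A few compounds are considered here, and "the series" means these few. Any claim that something is new, unique, unknown or untested is made for them only; others in the source may bear on it.

Measured so far:
compound 1, `CC(C)(C)N(NC(=O)c1ccccc1F)C(=O)c1ccccc1Cl`: 51.3 nM
compound 2, `CC(C)(C)N(NC(=O)c1ccccc1I)C(=O)c1ccccc1Cl`: 1290 nM

Compound 2 stands as the higher of the two numbers in an assay on cells for agonist activity at ecdysone receptor (Bombyx mori), read by a luciferase reporter, with a stated time of 24 h; a higher number here means that more compound is needed for the effect, a lower number that less compound is needed; its nearest neighbour is compound 1, which differs only by fluoro in place of iodo and gave the lower value, a gap told by a 25-fold higher number from compound 1 to compound 2 (1.40 log units; beyond the scatter). Compound 3, `Cc1ccccc1C(=O)NN(C(=O)c1ccccc1Cl)C(C)(C)C`, is not yet measured. It differs from compound 2 by methyl in place of iodo on an aromatic carbon, sitting on an aromatic carbon of a six-membered aromatic ring of carbon only, ortho to a large group. Within the data shown here, the one step that bears on this change, a 25-fold higher number from compound 1 to compound 2 (1.40 log units; beyond the scatter), was large, and it moved from the smallest halogen to the largest. Methyl stands between the two in size, so the number for compound 3 is expected to fall below that of compound 2, as a 5.9-fold lower number from compound 2 to compound 3 (0.77 log units; beyond the scatter), while probably not reaching compound 1. The estimate for compound 3 in this assay is 220 nM, with a range from 60 nM to 800 nM.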

Compound 3, half-maximal effective concentration: 72.4 nM
Compound 3: middle estimate off by 3.0-fold (0.48 log units), on the high side; low and high end bracket the measured number.
By their numbers in this assay, from the lowest: compounds 1 and 3 (each within the scatter of the next); then compound 2.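

In this assay, the high number of compound 2 proves not to apply to every group larger than fluoro at this aromatic carbon, since methyl in place of iodo takes back most of the earlier loss (an 18-fold lower number from compound 2 to compound 3 (1.25 log units; beyond the scatter)). Methyl in place of fluoro stays within the scatter (a 1.4-fold higher number from compound 1 to compound 3 (0.15 log units; within the scatter)), so fluoro and methyl cannot be told apart here, and among these three compounds only the iodo compound, compound 2, stands apart. Nothing at hand explains why iodo differs from the other two groups.

The compounds shown leave open how chloro, bromo or ethyl at this place would compare with fluoro, methyl and iodo. They also leave open whether a methoxy, an amine or a carboxylic acid here would keep the number of compound 3 or move towards that of compound 2.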